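Series notes: replacing the three-atom group of compound 3

This account rests on a few compounds, and the source may have more. Where it says the series, first, only, none or still open, it means among the compounds named here.

Three compounds carry numbers in a functional assay on the whole organism (Ear) for inhibition, with Mus musculus as the target, with a stated time of 30 min, at a dose of 100 mg/kg by the intraperitoneal route; on this read-out higher numbers stand for more inhibition at the one dose given (going by the name of the read-out) and lower numbers for less inhibition. Compound 1 `O=C(/C=C/c1ccc(/C=N/NC(=O)c2ccncc2)cc1)c1ccc(F)cc1` gives 51.1%. Among the compounds with values here, compound 2 `Cc1ccc(C(=O)/C=C/c2ccc(/C=N/NC(=O)c3ccncc3)cc2)c(C)c1` gives 58.5%; the only one-place step measured, a number 7.4 percentage points higher from compound 1 to compound 2 (within the scatter), is the change of the aryl group on the carbonyl carbon. Compound 3 `N=C(N)N/N=C/c1ccc(/C=C/C(=O)c2ccccc2Br)cc1` gives 78.3% and stands highest of the three, beyond the scatter from both compound 2 and compound 1.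

Compound 4 `O=C(N/N=C/c1ccc(/C=C/C(=O)c2ccccc2Br)cc1)c1ccncc1` is compound 3 with a group of 8 heavy atoms (6 carbon, 1 nitrogen, 1 oxygen; one six-membered aromatic ring with 1 hetero atom) in place of a group of 3 heavy atoms (1 carbon, 2 nitrogen; no ring), on an amine nitrogen, the new group being (pyridin-4-yl)carbonyl on the amine nitrogen whose other neighbour is a double-bonded nitrogen. Within the data shown here, no measured step covers this exchange. What bears on it indirectly: compound 1 and compound 2 already carry the (pyridin-4-yl)carbonyl group and sit below compound 3, while the aryl change in a number 7.4 percentage points higher from compound 1 to compound 2 (within the scatter) stayed within the scatter. A downward step is therefore expected, a number 18.3 percentage points lower from compound 3 to compound 4 (beyond the scatter), placing compound 4 near the values of compound 1 and compound 2. Compound 4 is estimated at 60%, in the range 45% to 75%.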

Compound 4, a percentage reported as inhibition, in the whole organism at one dose (the size of the read-out at that dose, not a potency): 48.7%
Compound 4: the middle estimate sits 11.3 percentage points above what was measured; measured number inside the range.
By their numbers in this assay, from the lowest: compounds 4, 1 and 2 (each within the scatter of the next); then compound 3.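

The exchange on the amine nitrogen now has a direct reading: with 2-bromophenyl held on the carbonyl carbon, this assay shows a number 29.6 percentage points lower from compound 3 to compound 4 (beyond the scatter) on going to the (pyridin-4-yl)carbonyl group. With that group held, the aryl exchanges give a number 9.8 percentage points lower from compound 2 to compound 4 (within the scatter) and a number 2.4 percentage points lower from compound 1 to compound 4 (within the scatter) for 2-bromophenyl, so 2-bromophenyl alone does not carry the high number of compound 3. Nothing measured here accounts for the size of the drop.

Open, going by these compounds, is whether the group of compound 3 keeps its number with 4-fluorophenyl or 2,4-dimethylphenyl on the carbonyl carbon. Also open, on these data alone, is how an acetyl or a benzoyl group would read on that amine nitrogen, relative to compound 3 and compound 4.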